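Aryl hydroxy to hydrogen across two cores

This account rests on a few compounds, and the source may have more. Where it says the series, first, only, none or still open, it means among the compounds named here.

Compound 1 `COc1cccc(C2SCC(=O)N2c2nnc(CNn3c(C)nc4ccc(Br)cc4c3=O)s2)c1`, compound 2 `COc1cc(C2SCC(=O)N2c2nnc(CNn3c(C)nc4ccc(Br)cc4c3=O)s2)ccc1O` and compound 3 `Cc1nc2ccccc2c(=O)n1NCc1nnc(/N=C/c2ccc(O)cc2)s1` have been run in a functional assay on the whole organism (strain albino) with Rattus norvegicus as the target, in the maximal electroshock model, with a stated time of 1 h, at a dose of 30 mg/kg by the intraperitoneal route; on this read-out lower numbers stand for less inhibition and higher numbers for more inhibition at the one dose given (going by the name of the read-out). Compound 1 gives 60%, compound 2 gives 60% and compound 3 gives 50%. On the core of compound 1 the change hydrogen in place of hydroxy on an aromatic carbon produced no change at the digits printed from compound 2 to compound 1 (within the scatter). Compound 4 `Cc1nc2ccccc2c(=O)n1NCc1nnc(/N=C/c2ccccc2)s1` has not yet been measured in this assay. It is reached from compound 3 by hydrogen in place of hydroxy on an aromatic carbon, the same kind of change, though here the place is not ortho to a methoxy group. The difference between the cores of compound 2 and compound 3 is not broken down here. Because the earlier step of no change at the digits printed from compound 2 to compound 1 (within the scatter) stayed within the scatter, the step from compound 3 to compound 4 is expected to be about no change at the digits printed from compound 3 to compound 4 (within the scatter). Compound 4 is therefore estimated at 50%, with a range from 35% to 65%.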

Compound 4, a percentage reported as inhibition, in the whole organism at one dose (the size of the read-out at that dose, not a potency): 50%
Estimate against measurement, compound 4: no gap at the digits printed, within the range that was stated.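

In this assay, hydrogen in place of hydroxy on an aromatic carbon gave no change at the digits printed from compound 3 to compound 4 (within the scatter). Set beside the earlier case, the change reads the same on both cores: the same change on two cores in this assay, no change at the digits printed (within the scatter) from compound 2 to compound 1 and no change at the digits printed (within the scatter) from compound 3 to compound 4, 0 percentage points apart, within the scatter of two such steps. This shows that, at this one dose, the change carries between these two cores without a difference beyond the scatter, but two pairs set no rule for the series and say nothing of other cores or of the size of the change at other doses.

The compounds shown leave open what an amine or a carboxylic acid would give at the same place on either core. Going by these compounds, a longer chain on the oxygen, as an ethoxy group, also stays open.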